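Ester to benzyl amide on the glycolate side chain

This account rests on a few compounds, and the source may have more. Where it says the series, first, only, none or still open, it means among the compounds named here.

Compound 2 `CCOC(=O)COc1nc(-c2ccc3c(c2)CCCC3)cc(-c2ccc(C(C)C)cc2)c1C#N` sits at the assay ceiling: in an ADME assay on RAW264.7 cells (Mus musculus) for cytotoxicity, with a stated time of 24 h (a lower number here means a stronger inhibitor, a higher number a weaker inhibitor), compound 2 gives > 50000 nM, a limit and not a number. Compound 1 `CC(C)c1ccc(-c2cc(-c3ccc4c(c3)CCCC4)nc(NCc3ccccc3)c2C#N)cc1` likewise gives > 50000 nM in this assay, again a limit. The step that the two limits leave unreadable from compound 1 to compound 2 is thus unreadable, as the limit of > 50000 nM in this assay, at which 2 of the 2 values shown sit, shows. Compound 3 `CC(C)c1ccc(-c2cc(-c3ccc4c(c3)CCCC4)nc(OCC(=O)NCc3ccccc3)c2C#N)cc1` differs from compound 2 by benzylamino in place of ethoxy on a carbonyl carbon. Going by the values given here, no measured step yields a size, so neither direction nor magnitude can be drawn from the pair; the only evidence is that both values rest at the limit. Compound 3 is expected to stay there, at an estimated 70000 nM (range 20000 nM to 250000 nM). The expected step that the limit leaves unreadable from compound 2 to compound 3 is therefore none beyond the scatter.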

Compound 3, half-maximal inhibitory concentration: 9900 nM
Compound 3: middle estimate off by 7.1-fold (0.85 log units), on the high side; measured number below the stated range.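

The glycolate side chain is the first position in the series where a single change gives a readable step in this assay: benzylamino in place of ethoxy on the carbonyl carbon gives an at least 5.0-fold lower number from compound 2 to compound 3 (0.70 log units; beyond the scatter). (Benzylcarbamoyl)methoxy in place of benzylamino on the aromatic carbon gives an at least 5.0-fold lower number from compound 1 to compound 3 (0.70 log units; beyond the scatter), so among these three compounds only the benzyl amide side chain brings a measurable number. Both sizes are open-ended, and the step between compound 1 and compound 2 cannot be read: the limit of > 50000 nM in this assay, at which 2 of the 3 values shown sit.

Going by these compounds, whether the amide hydrogen or the benzyl ring carries the step remains open. A dimethylamide, a simple methylamide or the carboxylic acid on the same side chain would separate the two.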